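Swapping 1-methylpiperidin-4-yl for 1-methylazetidin-3-yl

This account rests on a few compounds, and the source may have more. Where it says the series, first, only, none or still open, it means among the compounds named here.

In a physicochemical assay for solubility, read by spectrophotometry, measured as kinetic solubility, at pH 8, tested at 500 uM (a higher number here means a more soluble compound, a lower number a less soluble compound), compound 1 `CN1CCCC(NS(=O)(=O)c2ccccc2Nc2cc(-c3ccc4ccn(C)c4c3)c3nccnc3c2)C1` gives 9 ug/mL as its reading, and compound 2 `CN1CCC(NC(=O)c2ccncc2Nc2cc(-c3ccc4ccn(C)c4c3)c3nccnc3c2)CC1` gives 246 ug/mL as the higher of the two numbers, a gap beyond the usual scatter. Among the measured compounds shown here, compound 3 `CN1CC(NC(=O)c2ccncc2Nc2cc(-c3ccc4ccn(C)c4c3)c3nccnc3c2)C1` keeps the rest of compound 2 and carries 1-methylazetidin-3-yl in place of 1-methylpiperidin-4-yl on an amide-type nitrogen as its only change. For the measured compounds named here, no measured pair shows this swap, so no shift beyond the scatter is expected, and the estimated step of a 1.2-fold lower number from compound 2 to compound 3 (0.09 log units; within the scatter) is a small one. For compound 3 the estimated value is 200 ug/mL within an expected range of 110 ug/mL to 260 ug/mL when measured.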

Compound 3, solubility: 170 ug/mL
Compound 3: the middle estimate sits 1.2-fold (0.07 log units) above what was measured, within the range that was stated.
By their numbers in this assay, from the lowest: compound 1; then compounds 3 and 2 (each within the scatter of the next).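

Moving from the six-membered ring of 1-methylpiperidin-4-yl to the four-membered ring of 1-methylazetidin-3-yl on this amide-type nitrogen gives a 1.4-fold lower number from compound 2 to compound 3 (0.16 log units; within the scatter) in this assay. The two readings therefore cannot be told apart, so on this evidence the ring at this position can be made smaller without a measurable shift in this read-out. Nothing shown here accounts for that result. Still open, on these data alone, is how a longer chain ending in an amine, or a carboxylic acid, would read on this same nitrogen.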